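The source may report more compounds than this note shows. Statements on the series, on what has been measured and on what is new or still open speak of the compounds shown alone.

Compound 1 `O=C1C[C@H](O)CC(CCc2cccc3ccccc23)O1` stands at the higher end of the two numbers measured in an assay on isolated protein for inhibition of 3-hydroxy-3-methylglutaryl-coenzyme A reductase (Rattus norvegicus); on this read-out higher numbers stand for weaker inhibition and lower numbers for stronger inhibition: compound 1 gives 81000 nM, whereas compound 2 `Cc1cc(Cl)c2ccc(Cl)cc2c1CCC1C[C@@H](O)CC(=O)O1` gives 60 nM, a gap well beyond the scatter. Compound 2 differs from compound 1 in several places at once, so only the two values themselves can be set side by side. Compound 3 `O=C1C[C@H](O)CC(CCc2ccc(Br)c3ccccc23)O1` differs from compound 1 by bromo in place of hydrogen on an aromatic carbon. Within the data shown here, no single step of this kind has been measured here; a modest move toward stronger inhibition is expected, a 4.1-fold lower number from compound 1 to compound 3 (0.61 log units; beyond the scatter), though it may not clearly exceed the scatter. Compound 3 is thus expected to give 20000 nM, between 5000 nM and 60000 nM.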

Compound 3, half-maximal inhibitory concentration: 23300 nM
Compound 3: middle estimate off by 1.2-fold (0.07 log units), on the low side; the range from low to high includes it.
By their numbers in this assay, from the lowest: compound 2; then compound 3; then compound 1.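

In this assay, bromo in place of hydrogen on this aromatic carbon, para to a large group, gives a 3.5-fold lower number from compound 1 to compound 3 (0.54 log units; beyond the scatter), a modest but real gain in inhibition. This position therefore accepts a single heavy atom larger than hydrogen without loss of inhibition, and the number even falls. Nothing available here explains why the number moves.

As far as these compounds go, it remains open whether a different group on the same carbon, such as fluoro, methoxy or an amine, would lower the number further. From the compounds shown here alone, whether bromo would give a similar step on another core also stays unknown.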